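The source may report more compounds than this note shows. Statements on the series, on what has been measured and on what is new or still open speak of the compounds shown alone.

Compound 3 `Cc1ccc2nc(C(=O)Nc3c(F)cc(-c4cccc(F)c4)cc3F)c(C)c(C(=O)O)c2c1` stands highest of the three numbers measured in a functional assay on Hep 3B2 cells (Homo sapiens) for antiproliferative activity, read by MTT assay, with a stated time of 24 h, tested at 3.7 ug/mL (a lower number here means a weaker effect, a higher number a stronger effect of the compound at the concentration tested), giving 31.3%. Compound 1 `Cc1ccc2nc(C(=O)Nc3c(F)cc(-c4cccc(F)c4)cc3F)c(C)c(O)c2c1` gives 19.2% and compound 2 `Cc1c(C(=O)Nc2c(F)cc(-c3cccc(F)c3)cc2F)nc2ccc(F)cc2c1O` gives 22.3%. Going by the values given here, the step of a number 12.1 percentage points higher from compound 1 to compound 3 (beyond the scatter) is the only change beyond the scatter; the step of a number 3.1 percentage points higher from compound 1 to compound 2 (within the scatter) is not. Compound 4 `CCOc1ccc2nc(C(=O)Nc3c(F)cc(-c4cccc(F)c4)cc3F)c(C)c(C(=O)O)c2c1` differs from compound 3 by ethoxy in place of methyl on an aromatic carbon. Among the compounds with values here, the one measured step at this place is a number 3.1 percentage points higher from compound 1 to compound 2 (within the scatter), which stayed within the scatter, so no firm direction can be read from the data. A step of about a number 0.7 percentage points higher from compound 3 to compound 4 (within the scatter) is therefore expected, essentially none beyond the scatter. Compound 4 is estimated at 32%, within a range of 18% to 46%.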

Compound 4, a percentage reported as inhibition, at one concentration (the size of the read-out at that concentration, not a potency): 26.5%
Estimate against measurement, compound 4: 5.5 percentage points above; measured number inside the range.
By their numbers in this assay, from the lowest: compounds 1, 2, 4 and 3 (each within the scatter of the next, the first and the last beyond it).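

Ethoxy in place of methyl gave a number 4.8 percentage points lower from compound 3 to compound 4 (within the scatter) in this assay, so a group of three heavy atoms carrying a hydrogen-bond acceptor left the number at this position without a readable change. This extends what the fluoro step had suggested to a larger group and to a compound bearing the carboxy group. The data offer no evidence that bears on this result.

Going by these compounds, whether an amine or a longer chain such as butoxy here would move the number beyond the scatter stays open. So does whether ethoxy would behave alike in a compound bearing hydroxy instead of carboxy.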